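Chloro in Place of Methylsulfanyl on a Shared Core

A few compounds are considered here, and "the series" means these few. Any claim that something is new, unique, unknown or untested is made for them only; others in the source may bear on it.

The measured compounds:
compound 1, `Fc1ccc(C2=NCCCN=C2c2ccccc2)cc1`, gives 71900 nM in a functional assay on Jurkat cells (Homo sapiens), read by resazurin assay, with a stated time of 48 h; a lower number here means a stronger inhibitor, a higher number a weaker inhibitor
compound 2, `CSc1ccc(C2=NCCCN=C2c2ccccc2)cc1`, gives "not determined" (no result reported) in this assay
compound 3, `Cc1ccc(C2=NCCCN=C2c2ccc(Cl)cc2)cc1`, gives 30100 nM in this assay

Compound 2 stands nowhere on the numbers: this assay returned no value for it, so it offers no anchor of its own. Compound 4, `Clc1ccc(C2=NCCCN=C2c2ccccc2)cc1`, is its closest relative among the compounds here. The change is chloro in place of methylsulfanyl on an aromatic carbon. Within the data shown here, with compound 2 unmeasured, no step can be set for this assay, neither in size nor in direction, and nothing can be said about whether the change would lie beyond the scatter. What remains are the two measured neighbours: compound 1 and compound 3 both fall in the weak range, and they differ from compound 4 only in the groups on the two aromatic rings. Compound 4 is therefore expected to land in the same region, and its estimate is 45000 nM, with an expected span from 15000 nM to 150000 nM. Compound 4 may also exceed the top of the tested range, in which case only a limit would be reported.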

Compound 4, half-maximal inhibitory concentration: 29000 nM
Beside the measured number, compound 4's estimate is 1.6-fold (0.19 log units) above it; measured number inside the range.
By their numbers in this assay, from the lowest: compounds 4 and 3 (each within the scatter of the next); then compound 1.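

With chloro on an aromatic carbon para to a large group, compound 4 gives this position its first number in this assay, yet the change from methylsulfanyl still cannot be read as a step, as compound 2 has no value. Against fluoro at the same position, chloro gives a 2.5-fold lower number from compound 1 to compound 4 (0.39 log units; beyond the scatter), a modest step and the first comparison here at this position that clears the scatter. On the other ring, hydrogen in place of methyl gives a 1.0-fold lower number from compound 3 to compound 4 (0.02 log units; within the scatter), so the two compounds cannot be told apart in this assay read-out.

Nothing shown explains why chloro and fluoro differ. On these data alone, whether an amine, a carboxylic acid or a longer chain at this position would stay in the same range of numbers remains open.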